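The source may hold more compounds than are shown below. What is called first, only, known or untested is meant among the compounds shown, and "the series" means these compounds.

Compound 1 `CN(C)C(=S)N/N=C/c1ccc2ccccc2n1`, compound 2 `Fc1ccccc1NC(=S)N/N=C/c1ccc2ccccc2n1` and compound 3 `S=C(NCc1ccccc1)N/N=C/c1ccc2ccccc2n1` share one core and differ only in what sits on the amide-type nitrogen. In a functional assay on HL-60 cells (Homo sapiens) for antiproliferative activity, read by sulforhodamine B assay, with a stated time of 72 h (a lower number here means a stronger inhibitor, a higher number a weaker inhibitor), compound 1 gives 50 nM. For compound 2 this assay returns only a limit, > 100000 nM. Compound 3 gives 21900 nM, the highest of the two numbers shown, and it stands far above compound 1. Going by the values given here, the one measured step on this nitrogen is an at least 4.5-fold lower number from compound 2 to compound 3 (0.65 log units; beyond the scatter). Compound 4 `NC(=S)N/N=C/c1ccc2ccccc2n1` carries hydrogen in place of benzyl on an amide-type nitrogen. Among the compounds with values here, only that step bears on it, and it points toward a lower number as the group on the nitrogen shrinks, while compound 1 shows the lowest number of all. Compound 4 is therefore expected at 5000 nM (range 500 nM to 50000 nM), an estimated step of a 4.4-fold lower number from compound 3 to compound 4 (0.64 log units; beyond the scatter).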

Compound 4, half-maximal inhibitory concentration: > 100000 nM
Compound 4 was reported as a limit (the forecaster's own chance of this, stated with the estimate: 10%); middle value at least 20-fold (1.30 log units) from the limit.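

Compound 4's value is a limit, yet it still shows that stripping the nitrogen down to hydrogen does not continue the fall seen from the 2-fluorophenyl to the benzyl compound: hydrogen in place of benzyl gives an at least 4.5-fold higher number from compound 3 to compound 4 (0.65 log units; beyond the scatter) and so reverses the direction. Amino in place of dimethylamino gives an at least 2000-fold higher number from compound 1 to compound 4 (3.30 log units; beyond the scatter) and shows that the low number of compound 1 depends on its two methyl groups. The step between compound 2 and compound 4 cannot be read because both are limits: the limit of > 100000 nM in this assay, at which 2 of the 4 values shown sit.

On these data alone, whether a single methyl group on this nitrogen would restore activity remains open. So does the effect of a longer chain such as ethyl.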